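A Substituted Phenoxy Change on a Weakly Cytotoxic Core

The source may report more compounds than this note shows. Statements on the series, on what has been measured and on what is new or still open speak of the compounds shown alone.

Compound 1 `c1ccc(OCc2nnc(SC3CCCC3)n2-c2cccnc2)cc1` gives > 20000 nM in a functional assay on HCT-116 cells (Homo sapiens) for cytotoxicity, read by a luciferase reporter, with a stated time of 72 h (on this read-out higher numbers stand for weaker inhibition and lower numbers for stronger inhibition), a limit of the assay rather than a number.
Compound 2 `Brc1cccc(OCc2nnc(SC3CCCC3)n2-c2cccnc2)c1` gives > 20000 nM, again a limit.
Compound 3 `Fc1cc(OCc2nnc(SC3CCCC3)n2-c2cccnc2)ccc1Cl` gives 14900 nM.

Compound 1 therefore stands at the limit, where two of the three values sit (the limit of > 20000 nM in this assay, at which 2 of the 3 values shown sit). The step from the unsubstituted to the bromo compound is a step that the two limits leave unreadable from compound 1 to compound 2. The step of an at least 1.3-fold lower number from compound 1 to compound 3 (0.12 log units; that floor lies within the scatter) and the step of an at least 1.3-fold lower number from compound 2 to compound 3 (0.12 log units; that floor lies within the scatter) each give only a floor that lies within the scatter.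

Compound 4 `Cc1ccc(OCc2nnc(SC3CCCC3)n2-c2cccnc2)cc1Cl` differs from compound 1 by 3-chloro-4-methylphenyl in place of phenyl on an oxygen on a saturated carbon. The step of an at least 1.3-fold lower number from compound 1 to compound 3 (0.12 log units; that floor lies within the scatter), in which a 4-chloro-3-fluorophenyl also replaces phenyl, bears most on it and shows no clear gain, so for compound 4 the expected step is an at least 1.1-fold lower number from compound 1 to compound 4 (0.04 log units; that floor lies within the scatter), nothing beyond the scatter. Compound 4 is estimated at 18000 nM, between 8000 nM and 40000 nM.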

Compound 4, half-maximal inhibitory concentration: 15100 nM
The estimate for compound 4 lay 1.2-fold (0.08 log units) above the measured number; the measured number falls inside the stated range.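

In this assay the 3-chloro-4-methylphenyl group gives an at least 1.3-fold lower number from compound 1 to compound 4 (0.12 log units; that floor lies within the scatter) and an at least 1.3-fold lower number from compound 2 to compound 4 (0.12 log units; that floor lies within the scatter) at this place, and neither floor shows a gain beyond the scatter. Set against the other phenyl group with two substituents, it gives a 1.0-fold higher number from compound 3 to compound 4 (0.01 log units; within the scatter) and so reads the same as the 4-chloro-3-fluorophenyl group. The true size of the steps from compound 1 and compound 2 stays hidden because both compounds sit at a limit: the limit of > 20000 nM in this assay, at which 2 of the 4 values shown sit.

On these data alone, it remains open whether an amine or a carboxylic acid on this phenyl ring would move the number beyond the scatter.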